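A few compounds are considered here, and "the series" means these few. Any claim that something is new, unique, unknown or untested is made for them only; others in the source may bear on it.

Measured compounds:
- Compound 1 `CCc1ccc(C(=O)/C=C/c2ccc3c(c2)B(O)OC3)cc1`: > 10 ug/mL, a limit
- Compound 2 `O=C(/C=C/c1ccc2c(c1)B(O)OC2)c1ccc(OCc2ccccc2)cc1`: > 10 ug/mL, a limit

In an ADME assay on L929 cells (Mus musculus) for cytotoxicity, read by resazurin assay, with a stated time of 72 h (on this read-out higher numbers stand for weaker inhibition and lower numbers for stronger inhibition), compound 2 stands only at a limit, > 10 ug/mL. The measured series shows nothing firmer than the limit of > 10 ug/mL in this assay, at which 2 of the 2 values shown sit. Compound 3 `O=C(/C=C/c1ccc2c(c1)B(O)OC2)c1ccc(C(F)(F)F)cc1` follows from compound 2 by one change: trifluoromethyl in place of benzyloxy on an aromatic carbon. Among the measured compounds shown here, the only measured step that bears on it is a step that the two limits leave unreadable from compound 1 to compound 2. That step offers no size to carry over, so no change beyond the scatter is expected in this assay, and no direction can be given. The step expected is a step that the limit leaves unreadable from compound 2 to compound 3. For compound 3 the estimated value is 15 ug/mL, with an expected range of 5 ug/mL to 40 ug/mL.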

Compound 3, half-maximal inhibitory concentration: > 10 ug/mL
Compound 3: only a limit was reported; the forecaster's own chance of this, stated with the estimate: 75%; the middle value is on the limit's open side.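

Among the compounds shown here, no step among compound 1, compound 2 and compound 3 can be read in this assay, because all three stand at a limit: the limit of > 10 ug/mL in this assay, at which 3 of the 3 values shown sit. The compounds shown leave open how far each lies past that limit, and whether ethyl, benzyloxy or trifluoromethyl on the aromatic carbon changes the read-out at all.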